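Formylmethyl on the aromatic nitrogen: compound 3

A few compounds are considered here, and "the series" means these few. Any claim that something is new, unique, unknown or untested is made for them only; others in the source may bear on it.

In a functional assay on Hep 3B2 cells (Homo sapiens) for inhibition, read by sulforhodamine B assay, with a stated time of 5 days (on this read-out higher numbers stand for weaker inhibition and lower numbers for stronger inhibition), compound 1 `C=CS(=O)(=O)Nc1cccc(C)c1Nc1ncc(OCc2c(Cl)c(OC)cc(OC)c2Cl)cn1` gives 60000 nM and compound 2 `COc1cc(OC)c(Cl)c(COc2cnc(Nc3c(C)cccc3NC(=O)C3CO3)nc2)c1Cl` gives 59300 nM. Among the measured compounds shown here, these two values lie within the scatter of each other, so compound 2 does not stand apart from the only other measured compound.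

Compound 3 `COc1cc(OC)c(Cl)c(COc2cnc(Nc3c(C)cccc3NCC=O)nc2)c1Cl` follows from compound 2 by one change: formylmethyl in place of (oxiran-2-yl)carbonyl on a nitrogen on an aromatic ring. Formylmethyl takes the place of (oxiran-2-yl)carbonyl on a nitrogen on an aromatic ring.

For the measured compounds named here, only one measured step bears on this position: a 1.0-fold lower number from compound 1 to compound 2 (0.01 log units; within the scatter). That exchange of groups on the same nitrogen stayed within the scatter. Going by the values given here, no measured compound carries formylmethyl, so the evidence is thin and the range must stay wide.

In this assay the expected change is a 1.5-fold lower number from compound 2 to compound 3 (0.17 log units; within the scatter), which means no expected step beyond the scatter. For compound 3 the estimated value is 40000 nM, with an expected range of 10000 nM to 80000 nM.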

Compound 3, half-maximal inhibitory concentration: > 100000 nM
Compound 3: only a limit was reported (the forecaster's own chance of this, stated with the estimate: 15%); at least 2.5-fold (0.39 log units) between middle value and limit.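

In this assay compound 3 gives > 100000 nM, a limit and not a number: the limit of > 100000 nM in this assay, at which 1 of the 3 values shown sits.

Formylmethyl is the first group on this nitrogen to leave the read-out without a number, and the two steps it gives are floors only: an at least 1.6-fold higher number from compound 2 to compound 3 (0.22 log units; that floor lies within the scatter), and an at least 1.6-fold higher number from compound 1 to compound 3 (0.22 log units; that floor lies within the scatter). Neither floor establishes a change beyond the scatter, so vinylsulfonyl, (oxiran-2-yl)carbonyl and formylmethyl are not yet separated at this position, although the true size of both steps could be larger.

The compounds shown leave open how far past the limit compound 3 lies. They also leave open whether a plain amine, a carboxylic acid or a longer chain on this nitrogen would give a step beyond the scatter from compound 2.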